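Aryl exchange on compound 1

The source may hold more compounds than are shown below. What is called first, only, known or untested is meant among the compounds shown, and "the series" means these compounds.

Within the data shown here, in an ADME assay on KB cells (Homo sapiens) for cytotoxicity, read by MTT assay, with a stated time of 72 h (a lower number here means a stronger inhibitor, a higher number a weaker inhibitor), compound 1 `COc1ccc(OC)c(C2=C(c3cc(OC)c(OC)c(OC)c3)C(=O)CC2O[SiH2]C(C)(C)C)c1` gives 10 ug/mL, the only number in the set. Compound 2 `COc1ccc(OC)c(C2=C(c3cc(OC)c(OC)c(OC)c3)C(=O)CC2O)c1` gives > 100 ug/mL, which is a limit of the assay and not a number. Compound 3 `CCOC(=O)COc1ccc(C2=C(c3cc(OC)c(OC)c(OC)c3)C(=O)CC2O)cc1` gives > 100 ug/mL, again a limit. The series is thus bounded by the limit of > 100 ug/mL in this assay, at which 2 of the 3 values shown sit.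

Compound 4 `COc1cc(C2=C(c3cc(C)c(OC)c(C)c3)C(O[SiH2]C(C)(C)C)CC2=O)cc(OC)c1OC` departs from compound 1 in one place, with 4-methoxy-3,5-dimethylphenyl in place of 2,5-dimethoxyphenyl on a double-bonded ring carbon. Among the measured compounds shown here, the one measured step, an at least 10-fold higher number from compound 1 to compound 2 (1.00 log units; beyond the scatter), lies beyond the scatter, but it concerns the group on an oxygen on a saturated carbon, and compound 4 keeps that group. For the measured compounds named here, no measured step covers the aryl exchange itself, so the expectation rests on compound 1 at 10 ug/mL and carries a wide range. In this assay, the estimated step, no change at the digits printed from compound 1 to compound 4 (within the scatter), is expected to stay within the scatter, with neither direction favoured. The expected value for compound 4 is 10 ug/mL, with an estimated range of 3 ug/mL to 40 ug/mL.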

Compound 4, half-maximal inhibitory concentration: 40 ug/mL
Compound 4: the middle estimate sits 4.0-fold (0.60 log units) below what was measured; the range from low to high includes it.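

The aryl on the double-bonded ring carbon is a position that responds in this assay: with the group on the oxygen kept, 4-methoxy-3,5-dimethylphenyl in place of 2,5-dimethoxyphenyl gives a 4.0-fold higher number from compound 1 to compound 4 (0.60 log units; beyond the scatter), a modest step beyond the scatter. Among these compounds, this is the first readable change at this position, since the earlier step concerned only the group on the oxygen. Compound 4 still gives a number, 40 ug/mL. Compound 2 and compound 3 remain at a limit of the assay and not at a number: the limit of > 100 ug/mL in this assay, at which 2 of the 4 values shown sit.

The exchange alters the methoxy and methyl groups together, so the step cannot be divided among them. From the compounds shown here alone, whether an aryl bearing an amine or a carboxylic acid would keep a measurable number at this position remains open.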